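Removing the Aryl Group from the Amide Nitrogen

The source may hold more compounds than are shown below. What is called first, only, known or untested is meant among the compounds shown, and "the series" means these compounds.

Among the measured compounds shown here, compound 3 `Cc1ccc(N2C(=O)COc3ccc(-c4cccc(NS(=O)(=O)c5ccc(F)cc5)c4)cc32)cc1` is the only member of this small set to return a number in a functional assay on HCT-116 cells (Homo sapiens) for antiproliferative activity, read by MTT assay, with a stated time of 72 h; a lower number here means a stronger inhibitor, a higher number a weaker inhibitor: compound 3 gives 35600 nM. Compound 2 `O=C1COc2ccc(-c3cccc(NS(=O)(=O)c4ccc(F)cc4)c3)cc2N1c1ccc(F)cc1` reaches only the limit of the assay, > 40000 nM. Compound 1 `O=C1COc2ccc(-c3cnc(Cl)c(NS(=O)(=O)c4ccc(F)cc4)c3)cc2N1`, which also carries a hydrogen on the amide-type nitrogen in the ring but differs elsewhere as well, likewise stops at the limit, > 40000 nM. For the measured compounds named here, the single measured step, an at least 1.1-fold lower number from compound 2 to compound 3 (0.05 log units; that floor lies within the scatter), lies within the scatter and concerns a different part of the molecule. Compound 4 `O=C1COc2ccc(-c3cccc(NS(=O)(=O)c4ccc(F)cc4)c3)cc2N1` has not yet been measured; it differs from compound 3 by hydrogen in place of 4-methylphenyl on an amide-type nitrogen in a ring. Going by the values given here, no measured step bears directly on this change, and two of the three values shown sit at the limit of > 40000 nM in this assay, at which 2 of the 3 values shown sit, so little can be drawn from the set. The step of a 1.1-fold higher number from compound 3 to compound 4 (0.05 log units; within the scatter) is expected to lie within the scatter, with a real chance that only a limit is reported. The estimate for compound 4 is 40000 nM, with a range from 15000 nM to 120000 nM.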

Compound 4, half-maximal inhibitory concentration: > 40000 nM
Compound 4 gave a limit, no number; the forecaster's own chance of this, stated with the estimate: 60%; the middle value sits exactly at the limit.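

In this assay, the amide-type nitrogen in the ring now has a direct comparison: hydrogen in place of 4-methylphenyl gives an at least 1.1-fold higher number from compound 3 to compound 4 (0.05 log units; that floor lies within the scatter). Only the floor of this step is known, so the result does not show that the 4-methylphenyl group matters here, and it does not show that it is dispensable; compound 4 simply returns a limit and no number. The step from compound 2 to compound 4 cannot be read, and the set now rests largely on one boundary: the limit of > 40000 nM in this assay, at which 3 of the 4 values shown sit.

What the compounds shown leave open is whether a group other than hydrogen or a substituted phenyl on this nitrogen, such as a chain ending in an amine or a carboxylic acid, would give a number in this assay. From the compounds shown here alone, how far compound 4 really lies from compound 3 also remains open.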